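The source may report more compounds than this note shows. Statements on the series, on what has been measured and on what is new or still open speak of the compounds shown alone.

Of the compounds shown here, three built on the same core have been tested in a functional assay on GTL 16 cells for antiproliferative activity against GTL 16 cell line (Homo sapiens), read by CCK-8 assay, with a stated time of 72 h; a lower number here means a stronger inhibitor, a higher number a weaker inhibitor. Compound 1 `COc1ccc(C(=O)Nc2cccc(-c3oc4cc(-c5ccc(F)cc5)ccc4c(=O)c3O)c2)cc1` gives 21100 nM. Compound 2 `O=C(Nc1cccc(-c2oc3cc(-c4ccc(F)cc4)ccc3c(=O)c2O)c1)c1ccc(Cl)cc1` gives 9140 nM. Compound 3 `COc1ccc(C(=O)Nc2cccc(-c3oc4cc(-c5ccc(F)cc5)ccc4c(=O)c3O)c2)c(F)c1` gives 15300 nM. Compound 2 stands lowest of the three numbers: a 2.3-fold lower number from compound 1 to compound 2 (0.36 log units; beyond the scatter), a modest step beyond the scatter, whereas its gap to compound 3, a 1.7-fold higher number from compound 2 to compound 3 (0.22 log units; within the scatter), lies within the scatter, so compound 2 and compound 3 cannot be told apart.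

Compound 4 `N#Cc1ccc(C(=O)Nc2cccc(-c3oc4cc(-c5ccc(F)cc5)ccc4c(=O)c3O)c2)cc1` differs from compound 2 in one place: cyano in place of chloro on an aromatic carbon. For the measured compounds named here, the only measured step at this place on the ring is the one from methoxy to chloro, which gave the modest change already described. Going by the values given here, no measured step involves cyano. The other steps, a 1.4-fold lower number from compound 1 to compound 3 (0.14 log units; within the scatter) and a 1.7-fold higher number from compound 2 to compound 3 (0.22 log units; within the scatter), touch other parts of the amide substituent and both fall within the scatter, so the numbers seen so far vary little across this series. The step from compound 2 to compound 4 is therefore expected to be small, with a lean toward a higher number since compound 2 holds the lowest value seen. Compound 4 is expected to show a 1.4-fold higher number from compound 2 to compound 4 (0.15 log units; within the scatter). Compound 4 is estimated at 13000 nM, within a range from 5000 nM to 32000 nM.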

Compound 4, half-maximal inhibitory concentration: 31800 nM
Compound 4: the middle estimate sits 2.4-fold (0.39 log units) below what was measured; the range from low to high includes it.
By their numbers in this assay, from the lowest: compounds 2, 3, 1 and 4 (each within the scatter of the next, the first and the last beyond it).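

In this assay, the place para to a large group on the benzoyl ring now shows a wider spread, since replacing chloro with cyano gives a 3.5-fold higher number from compound 2 to compound 4 (0.54 log units; beyond the scatter), a step larger than the one from methoxy to chloro, and in the opposite direction to it. Cyano and methoxy cannot be told apart here (a 1.5-fold higher number from compound 1 to compound 4 (0.18 log units; within the scatter)), so among the three groups at this place only chloro separates from the others, and a nitrile brings no gain over methoxy in this series, while compound 4 also separates from the fluorinated methoxy compound (a 2.1-fold higher number from compound 3 to compound 4 (0.32 log units; beyond the scatter)). Nothing shown here accounts for why chloro stands apart from cyano and methoxy at this place.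

As far as these compounds go, it remains open whether chloro's standing reflects something particular to that group, or whether bromo, trifluoromethyl, an amine or a carboxylic acid at the same place would fall with compound 2 or with compound 1 and compound 4. From the compounds shown here alone, it is also open whether the fluoro that compound 3 adds to the methoxy ring would shift the number when paired with chloro or cyano.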